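From Methyl to Isopropyl on the Amine Nitrogen

This account rests on a few compounds, and the source may have more. Where it says the series, first, only, none or still open, it means among the compounds named here.

Three close relatives share one core. In an assay for inhibition of tRNA (cytosine(38)-C(5))-methyltransferase (Homo sapiens), with a stated time of 5 min, tested at 100 uM (on this read-out higher numbers stand for more inhibition at the one concentration tested (going by the name of the read-out) and lower numbers for less inhibition), compound 1 `NCCCSC[C@H]1O[C@@H](n2cnc3c(N)ncnc32)[C@H](O)[C@@H]1O` gives no result reported. Within the data shown here, compound 2 `CN(CC[C@H](N)C(=O)O)C[C@H]1O[C@@H](n2cnc3c(N)ncnc32)[C@H](O)[C@@H]1O` is therefore the only point with a number: in this assay compound 2 gives 30.3%, so at the single concentration tested it blocks the enzyme only partly. Compound 3 `CC(C)N(CC[C@H](N)C(=O)O)C[C@H]1O[C@@H](n2cnc3c(N)ncnc32)[C@H](O)[C@@H]1O` has not been measured yet. It differs from compound 2 in one place only (isopropyl in place of methyl on an amine nitrogen). Among the measured compounds shown here, with no comparable step between measured compounds to lean on, the change can only be read on its own. One methyl swapped for an isopropyl on the amine nitrogen gives little ground to expect a shift in this assay beyond the scatter, in either direction. The estimated step of a number 2.3 percentage points lower from compound 2 to compound 3 (within the scatter) is therefore expected to be small. Compound 3 is estimated to give 28%, within a range from 10% to 50%.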

Compound 3, a percentage reported as inhibition, at one concentration (the size of the read-out at that concentration, not a potency): 44%
Estimate against measurement, compound 3: 16 percentage points below; low and high end bracket the measured number.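

In this assay, the amine nitrogen proves to be a position that responds: a number 13.7 percentage points higher from compound 2 to compound 3 (beyond the scatter) comes with isopropyl in place of methyl on that nitrogen. The change adds only carbon, with no ring, no hydrogen-bond donor or acceptor and no net charge entering or leaving, yet the read-out moves toward more inhibition at the one concentration tested. Nothing at hand accounts for this rise, so its cause stays unknown.

Steps involving compound 1 cannot be read, as it has no reported number and so offers no comparison. As far as these compounds go, with a single step at this nitrogen, it remains open whether an ethyl, a cyclopropyl or a benzyl group there would carry the read-out further, or whether a plain hydrogen would lower it.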